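A few compounds are considered here, and "the series" means these few. Any claim that something is new, unique, unknown or untested is made for them only; others in the source may bear on it.

Series notes. Compound 1 `CCCC[S+]([O-])c1sc2nc(-c3nccs3)cc(-c3ccc(C(C)(C)O)cc3)c2c1N` and compound 2 `CCCC[S+]([O-])c1sc2nc(-c3nccs3)cc(-c3ccc(C(=O)OC)cc3)c2c1N` share one core and differ only in the group carried on the phenyl ring. In an assay for inhibition of 15-hydroxyprostaglandin dehydrogenase [NAD(+)] (Homo sapiens), read by fluorescence, with a stated time of 15 min, in the presence of a further agent that is not named here (a higher number here means a weaker inhibitor, a lower number a stronger inhibitor), compound 1 gives 3.6 nM, and compound 2 gives 15.1 nM. The measured step of a 4.2-fold higher number from compound 1 to compound 2 (0.62 log units; beyond the scatter) is the only one so far, and compound 2 therefore stands as the higher of the two numbers. Compound 3 `CCCC[S+]([O-])c1sc2nc(-c3nccs3)cc(-c3ccc(CCO)cc3)c2c1N` carries the next change: 2-hydroxyethyl in place of methoxycarbonyl on an aromatic carbon. Going by the values given here, the one step that bears on it is a 4.2-fold higher number from compound 1 to compound 2 (0.62 log units; beyond the scatter), in which a hydroxyl-bearing group gave way to the ester and the number rose. Compound 3 runs the other way, with the ester leaving and a hydroxyl-bearing chain entering, so a step toward a lower number is expected, of roughly comparable size or somewhat smaller. For compound 3 the expected step is a 2.5-fold lower number from compound 2 to compound 3 (0.40 log units; beyond the scatter). Compound 3 is estimated at 6 nM, with a range from 2.5 nM to 15 nM.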

Compound 3, half-maximal inhibitory concentration: 2.9 nM
Beside the measured number, compound 3's estimate is 2.1-fold (0.32 log units) above it; low and high end bracket the measured number.
By their numbers in this assay, from the lowest: compounds 3 and 1 (each within the scatter of the next); then compound 2.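

In this assay, the exchange of methoxycarbonyl for 2-hydroxyethyl on the phenyl ring gives a 5.2-fold lower number from compound 2 to compound 3 (0.72 log units; beyond the scatter), so the change away from the ester now has a second example, this time with a different hydroxyl-bearing group. The two hydroxyl-bearing groups are not separated by this assay, with a 1.2-fold lower number from compound 1 to compound 3 (0.09 log units; within the scatter): the branched 1-hydroxy-1-methylethyl and the unbranched 2-hydroxyethyl read alike, and among these three compounds only the ester, compound 2, stands apart. Nothing measured here accounts for the difference between the ester and the two hydroxyl-bearing groups.

From the compounds shown here alone, how a plain ethyl group, a 2-methoxyethyl group or a 2-aminoethyl chain would read on this carbon remains open, so the hydroxyl's contribution cannot yet be separated from that of the chain. A carboxylic acid and a longer 3-hydroxypropyl chain are equally untested in the compounds shown.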